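Imidazolyl for Pyrrolidinyl on Two Carbamate Cores

A few compounds are considered here, and "the series" means these few. Any claim that something is new, unique, unknown or untested is made for them only; others in the source may bear on it.

Compound 1 `COC(=O)N(C)CC#CCN1CCCC1` and compound 2 `COC(=O)N(C)CC#CCn1ccnc1` share one core, while compound 3 `CCOC(=O)N(C)C(C)C#CCN1CCCC1` and compound 4 `CCOC(=O)N(C)C(C)C#CCn1ccnc1` share another; the difference between the two cores is not broken down here. In a functional assay on the whole organism for antagonist activity, with Mus musculus as the target (a lower number here means that less compound is needed, a higher number that more compound is needed for the effect), compound 1 gives only a limit, > 10 mg/kg. Compound 2 likewise reaches only a limit in this assay, > 100 mg/kg. The change between them is 1H-imidazol-1-yl in place of pyrrolidin-1-yl on a saturated chain carbon bound to a triple-bonded carbon, and the step it made, a step that the two limits leave unreadable from compound 1 to compound 2, cannot be sized since the limit of > 10 mg/kg in this assay, at which 1 of the 3 values shown sits, and the limit of > 100 mg/kg in this assay, at which 2 of the 3 values shown sit, are both limits. Compound 3 also gives only a limit in this assay, > 100 mg/kg. Compound 4 differs from compound 3 by 1H-imidazol-1-yl in place of pyrrolidin-1-yl on a saturated chain carbon bound to a triple-bonded carbon, the same change at the same place. The expectation for compound 4 rests on compound 3 standing at a limit, > 100 mg/kg, and on the step from compound 1 to compound 2 being unreadable. Compound 4 is expected to show a step that the limit leaves unreadable from compound 3 to compound 4 in this assay. Compound 4 is estimated at 300 mg/kg in this assay, between 100 mg/kg and 1000 mg/kg, and most likely as only a limit.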

Compound 4, dose for half-maximal effect: > 100 mg/kg
Compound 4 ended at the assay's limit (the forecaster's own chance of this, stated with the estimate: 90%); the middle value is on the limit's open side.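

No step can be read from compound 3 to compound 4, since in this assay the two compounds give only limits: the limit of > 100 mg/kg in this assay, at which 3 of the 4 values shown sit.

The compounds shown leave open what 1H-imidazol-1-yl in place of pyrrolidin-1-yl does to the dose needed on either core, and whether that change has the same size on both.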